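Iodo for Methyl on the Anilino Ring

The source may hold more compounds than are shown below. What is called first, only, known or untested is meant among the compounds shown, and "the series" means these compounds.

Compound 2 `COc1cc(NC(=O)Nc2cc(Nc3ccc(OC)c(C)c3)ncn2)cc(OC)c1` gives 62% in a functional assay on PC-9 cells (Homo sapiens) for inhibition, read by MTT assay, with a stated time of 48 h, tested at 10 uM (on this read-out lower numbers stand for less inhibition and higher numbers for more inhibition at the one concentration tested (going by the name of the read-out)), and stands lowest of the two numbers measured; compound 1 `COc1cc(NC(=O)Nc2cc(Nc3ccc(C)c(F)c3)ncn2)cc(OC)c1` gives 77.5%. For the measured compounds named here, the only measured step, a number 15.5 percentage points lower from compound 1 to compound 2 (beyond the scatter), exchanged the whole anilino ring. Compound 3 `COc1cc(NC(=O)Nc2cc(Nc3ccc(OC)c(I)c3)ncn2)cc(OC)c1` differs from compound 2 by iodo in place of methyl on an aromatic carbon. Going by the values given here, no step in these data isolates this exchange, so the expectation rests on the single-ring swap alone. Compound 3 is therefore estimated at 65%, between 45% and 85%, a step of a number 3 percentage points higher from compound 2 to compound 3 (within the scatter) that is expected not to exceed the scatter.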

Compound 3, a percentage reported as inhibition, at one concentration (the size of the read-out at that concentration, not a potency): 47.1%
Compound 3: middle estimate off by 17.9 percentage points, on the high side; the range from low to high includes it.
By their numbers in this assay, from the lowest: compound 3; then compound 2; then compound 1.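

In this assay the swap of methyl for iodo on this aromatic carbon, ortho to a methoxy group, gives a number 14.9 percentage points lower from compound 2 to compound 3 (beyond the scatter) on its own, so one atom here shifts the read-out about as far as the whole-ring exchange did. Against the 3-fluoro-4-methylphenyl ring, the 3-iodo-4-methoxyphenyl ring gives a number 30.4 percentage points lower from compound 1 to compound 3 (beyond the scatter) in all. No evidence at hand accounts for this drop. Going by these compounds, whether chloro, bromo or an amine on this carbon would keep the read-out nearer that of compound 2 remains open.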